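Loss of the fluoro group in compound 3

The compounds below may be only part of what the source reports. "The series", "measured", "known", "first", "only" and "open" are said of these compounds alone.

Compound 3 `Nc1ccccc1NC(=O)c1ccc(CSC(=S)N2CCN(c3ccccc3F)CC2)cc1` sits at the top of the three numbers measured in a functional assay on MGC-803 cells (Homo sapiens) for antiproliferative activity, read by CCK-8 assay, with a stated time of 72 h, tested at 8 uM (on this read-out higher numbers stand for a stronger effect at the one concentration tested and lower numbers for a weaker effect), where compound 3 gives 86.4%. Compound 1 `Nc1ccccc1NC(=O)c1ccc(CSC(=S)N2CCN(Cc3ccncc3)CC2)cc1` gives 79.3%, and the step of a number 7.1 percentage points higher from compound 1 to compound 3 (within the scatter) is within the scatter, so the two cannot be ordered. Compound 2 `COc1ccc(N2CCN(C(=S)SCc3ccc(C(=O)Nc4ccccc4N)cc3)CC2)cc1` gives 22.9%; the steps of a number 56.4 percentage points lower from compound 1 to compound 2 (beyond the scatter) and a number 63.5 percentage points higher from compound 2 to compound 3 (beyond the scatter) are large and beyond the scatter, so compound 2 stands clearly below the other two.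

Compound 4 `Nc1ccccc1NC(=O)c1ccc(CSC(=S)N2CCN(c3ccccc3)CC2)cc1` differs from compound 3 by hydrogen in place of fluoro on an aromatic carbon, that is, 2-fluorophenyl to phenyl on the amine nitrogen in the ring. Within the data shown here, no measured step exchanges only a fluoro for a hydrogen; the steps to compound 3 each replace the whole group on that nitrogen. They show that an aryl group carrying the fluoro and the (pyridin-4-yl)methyl group land within the scatter of each other, while the 4-methoxyphenyl group falls far below. The removal of a single fluorine is a smaller change than any of these.

The step of a number 7.4 percentage points lower from compound 3 to compound 4 (within the scatter) is therefore expected to stay within the scatter, with a slight downward lean as the more likely case. For compound 4 the estimate in this assay is 79%, with a range from 60% to 92%.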

Compound 4, a percentage reported as inhibition, at one concentration (the size of the read-out at that concentration, not a potency): 87.4%
For compound 4 the middle estimate is 8.4 percentage points below the measured one; the measured number falls inside the stated range.
By their numbers in this assay, from the lowest: compound 2; then compounds 1, 3 and 4 (each within the scatter of the next).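

In this assay, the fluoro on the aromatic carbon ortho to a large group turns out not to be needed for the read-out at this one concentration, with a number 1 percentage points higher from compound 3 to compound 4 (within the scatter), so the plain phenyl holds the effect as well as the 2-fluorophenyl does. The step of a number 64.5 percentage points higher from compound 2 to compound 4 (beyond the scatter) now ties the large loss to a single change, the removal of the methoxy group, so the aryl group on the ring nitrogen is not itself the liability, while a number 8.1 percentage points higher from compound 1 to compound 4 (within the scatter) leaves phenyl and (pyridin-4-yl)methyl indistinguishable on this read-out. No supporting data bear on why the methoxy change carries so much weight and the fluoro change so little.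

Still open, on these data alone, is whether the loss belongs to the methoxy group itself or to where it sits on the ring, which a 2-methoxyphenyl analogue would separate. Also open, as far as these compounds go, is how a chloro, methyl or hydroxy group on the phenyl ring would behave, and whether the near-equal single-concentration numbers hide potency differences.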